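This account rests on a few compounds, and the source may have more. Where it says the series, first, only, none or still open, it means among the compounds named here.

Measured compounds:
- compound 1, `Cc1ccc(Oc2ccc(CC3SC(=O)NC3=O)cc2)cc1`, 547 nM
- compound 2, `Cc1ccc(Oc2ccc(CC3SC(=O)NC3=O)cc2)c(C)c1`, 121 nM

Both were tested in a functional assay for agonist activity at Free fatty acid receptor 1 (Homo sapiens), read by FLIPR, in the presence of a further agent that is not named here; a higher number here means that more compound is needed for the effect, a lower number that less compound is needed. Of the two, compound 1 has the highest number, and its nearest neighbour is compound 2, which differs by one methyl in place of hydrogen on an aromatic carbon; that step, a 4.5-fold lower number from compound 1 to compound 2 (0.66 log units; beyond the scatter), was modest but beyond the scatter.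

The unmeasured compound 3, `O=C1NC(=O)C(Cc2ccc(Oc3ccc(Cl)cc3)cc2)S1`, differs from compound 1 in one place: chloro in place of methyl on an aromatic carbon. Going by the values given here, the only measured step concerns adding a methyl elsewhere on the ring, so no measured step directly bears on swapping one small group for another of the same size. Because the change is a like-for-like exchange of single atoms and compound 1 sits at 547 nM, the expected step of a 1.2-fold lower number from compound 1 to compound 3 (0.08 log units; within the scatter) is none beyond the scatter. The estimate for compound 3 is therefore 450 nM, within 150 nM to 1400 nM.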

Compound 3, half-maximal effective concentration: 240 nM
Compound 3: middle estimate off by 1.9-fold (0.27 log units), on the high side; measured number inside the range.
By their numbers in this assay, from the lowest: compounds 2 and 3 (each within the scatter of the next); then compound 1.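

In this assay, the aromatic carbon para to a large group proves sensitive to which small group it carries: going from 4-methylphenyl to 4-chlorophenyl gives a 2.3-fold lower number from compound 1 to compound 3 (0.36 log units; beyond the scatter), a modest step. The earlier step added a methyl at another place on this ring, so it said nothing about this carbon. This result shows that exchanging one heavy atom here, with no hydrogen-bond donor, acceptor or net charge entering or leaving, can still move the number beyond the scatter. Nothing available explains why chloro gives the lower number at this position.

Going by these compounds, whether fluoro, methoxy or trifluoromethyl at this carbon would lower the number further remains open. So does whether chloro here, combined with the added methyl of compound 2, would lower it further than either change alone.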